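1-methylbutyl to sec-butyl on the shared core

This account rests on a few compounds, and the source may have more. Where it says the series, first, only, none or still open, it means among the compounds named here.

Of the compounds shown here, three on the shared core have been read in an ADME assay on Huh-7 cells (Homo sapiens) for cytotoxicity, with a stated time of 72 h (on this read-out higher numbers stand for lower toxicity in this test and lower numbers for higher toxicity in this test), and none gives a number. Compound 1 `CS(=O)(=O)Nc1ccc2c(c1)S(=O)(=O)N=C(c1c(O)c(-c3cccs3)nn(CC3CCC3)c1=O)N2` gives > 1000 nM, which is a limit. Compound 2 `COC(C)(C)CCn1nc(-c2cccs2)c(O)c(C2=NS(=O)(=O)c3cc(NS(C)(=O)=O)ccc3N2)c1=O` gives > 33000 nM, also a limit. Compound 3 `CCCC(C)n1nc(-c2cccs2)c(O)c(C2=NS(=O)(=O)c3cc(NS(C)(=O)=O)ccc3N2)c1=O` gives > 33000 nM, again a limit. Compound 3 therefore stands at the limit of > 33000 nM in this assay, at which 2 of the 3 values shown sit.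

Compound 4 `CCC(C)n1nc(-c2cccs2)c(O)c(C2=NS(=O)(=O)c3cc(NS(C)(=O)=O)ccc3N2)c1=O` differs from compound 3 by hydrogen in place of methyl on a saturated chain carbon, three bonds along the chain from an aromatic nitrogen. In words, this is hydrogen in place of methyl on a saturated chain carbon, three bonds along the chain from an aromatic nitrogen, or 1-methylbutyl to sec-butyl.

Three measured steps change the same substituent: a step that the two limits leave unreadable from compound 1 to compound 3, a step that the two limits leave unreadable from compound 2 to compound 3 and a step that the two limits leave unreadable from compound 1 to compound 2. None has a readable size, so none sizes this change. The expectation rests on compound 3 and its place at the limit of > 33000 nM in this assay, at which 2 of the 3 values shown sit. No shift in either direction beyond the usual scatter is expected, and the estimated move is a number no higher from compound 3 to compound 4 (the limit leaves the size open). Compound 4 is expected at about 33000 nM, with an estimated range from 12000 nM to 60000 nM.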

Compound 4, half-maximal cytotoxic concentration: > 33000 nM
Compound 4 ended at the assay's limit; the forecaster's own chance of this, stated with the estimate: 85%; the middle value sits exactly at the limit.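

Compound 4 gives only a limit, as do compound 1, compound 2 and compound 3, so none of the steps to compound 4 can be read. The compounds shown leave open where any of the four stands in this assay, and whether the substituent on the aromatic nitrogen changes the read-out at all.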